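This account rests on a few compounds, and the source may have more. Where it says the series, first, only, none or still open, it means among the compounds named here.

Compound 1 `O=C(CSc1nnc(NC(=O)CCCCl)s1)Nc1ccc(Cl)cn1`: in a functional assay on A875 cells (Homo sapiens) for antiproliferative activity, read by MTT assay, with a stated time of 48 h (a higher number here means a weaker inhibitor, a lower number a stronger inhibitor), compound 1 gives > 80000 nM, which is a limit of the assay and not a number.
Compound 2 `O=C(CCl)Nc1ccc(SCC(=O)Nc2ccc(Cl)cn2)cc1`: in this assay compound 2 gives 98 nM.
Compound 3 `O=C(CCl)Nc1ccc(SCC(=O)Nc2cc(Cl)ccn2)cc1`: in this assay compound 3 gives 850 nM.

Of the two numbers shown, compound 3 has the higher one, so it is the weaker inhibitor of the pair. The only step shown between neighbours is an 8.7-fold higher number from compound 2 to compound 3 (0.94 log units; beyond the scatter), in which 4-chloropyridin-2-yl replaces 5-chloropyridin-2-yl on an amide-type nitrogen; it shows that where the chloro sits on that ring changes the result. Compound 4 `O=C(CCl)Nc1ccc(SCC(=O)Nc2ccccn2)cc1` differs from compound 3 by hydrogen in place of chloro on an aromatic carbon, placed meta to a large group and opposite the ring nitrogen; in words, hydrogen in place of chloro on an aromatic carbon. Within the data shown here, no measured step removes a chloro outright, so the direction is uncertain. The step of a 1.7-fold lower number from compound 3 to compound 4 (0.23 log units; within the scatter) is therefore expected to be small, with the chance of movement either way. Compound 4 is estimated at 500 nM, with a range from 100 nM to 3000 nM.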

Compound 4, half-maximal inhibitory concentration: 17200 nM
Estimate against measurement, compound 4: 34-fold (1.54 log units) below, and the stated range ends below it.
By their numbers in this assay, from the lowest: compound 2; then compound 3; then compound 4. At a limit, above all of these: compound 1.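

The earlier compounds shown here compared only two places for the chloro, whereas this result shows that having a chloro on the ring matters at all in this assay: going from 4-chloropyridin-2-yl to pyridin-2-yl gives a 20-fold higher number from compound 3 to compound 4 (1.31 log units; beyond the scatter). The same loss from the other chloro place, 5-chloropyridin-2-yl, gives a 180-fold higher number from compound 2 to compound 4 (2.24 log units; beyond the scatter). So at both places shown, the compound with chloro has a clearly lower number than the compound with hydrogen, and this holds for every pair compared here.

Nothing measured here gives a reason for these large steps. On these data alone, it remains open whether chloro is needed as such, or whether a bromo, a methyl or a methoxy group at either place would keep the number close to that of compound 2.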